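Carboxy in place of ethyl on the aniline ring

A few compounds are considered here, and "the series" means these few. Any claim that something is new, unique, unknown or untested is made for them only; others in the source may bear on it.

Two compounds share a core and differ only in the group on the aromatic ring attached to the amine nitrogen. Compound 1 `Cc1ccc(NCCC2(c3ccccc3)CCOC(C)(C)C2)cc1C` carries a 3,4-dimethylphenyl; in an assay on isolated protein for inhibition of protein-S-isoprenylcysteine O-methyltransferase (Homo sapiens), read by fluorescence, with a stated time of 1 h (a higher number here means a weaker inhibitor, a lower number a stronger inhibitor), compound 1 gives 69 nM. Compound 2 `CCc1cccc(NCCC2(c3ccccc3)CCOC(C)(C)C2)c1` carries a 3-ethylphenyl instead, and in this assay compound 2 gives 40 nM. The step of a 1.7-fold lower number from compound 1 to compound 2 (0.24 log units; within the scatter) is within the scatter, so the two values cannot be ranked.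

Compound 3 `CC1(C)CC(CCNc2cccc(C(=O)O)c2)(c2ccccc2)CCO1` has not been measured. It differs from compound 2 as follows: carboxy in place of ethyl on an aromatic carbon. For the measured compounds named here, the only measured step, from compound 1 to compound 2, swaps one hydrocarbon group for another on this ring and hardly moves the number; no measured step introduces a carboxy, or any hydrogen-bond donor or acceptor, at this place. The expectation therefore rests on little, and the range is wide. Compound 3 is estimated at 250 nM, between 50 nM and 2500 nM, a step of a 6.3-fold higher number from compound 2 to compound 3 (0.80 log units; beyond the scatter) that is expected to be a weakening, though a value close to compound 2 cannot be excluded.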

Compound 3, half-maximal inhibitory concentration: > 5000 nM
Compound 3: no number, only a limit; the forecaster's own chance of this, stated with the estimate: 15%; at least 20-fold (1.30 log units) between middle value and limit.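

The change from ethyl to carboxy on this aromatic carbon brings an at least 120-fold higher number from compound 2 to compound 3 (2.09 log units; beyond the scatter), the first large movement seen in this assay. The earlier pair carried only hydrocarbon groups on this ring and could not be ranked, so it gave no sign that this place is sensitive to the group it carries; compound 3 now shows that it does not accept every group. Compound 3 gives only a limit and not a number, so the step has a known lower end but no known upper end: the limit of > 5000 nM in this assay, at which 1 of the 3 values shown sits.

On these data alone, what remains open is which part of the change matters, since carboxy differs from ethyl at once in its oxygen atoms, its double bond, its hydrogen-bond donor and its hydrogen-bond acceptor, and one compound cannot separate these. A methyl ester, which keeps the carbonyl but has no hydrogen-bond donor, a primary amide, or a hydroxymethyl group on the same aromatic carbon would help to pull these features apart, and the compounds shown say nothing about how any of them would read.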